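Two Aryl Isoxazoles and a Thiophene Yet to Be Measured

The source may report more compounds than this note shows. Statements on the series, on what has been measured and on what is new or still open speak of the compounds shown alone.

Two compounds share a piperidinyl-pyrazole core joined to an isoxazole that carries an aryl group. Compound 1 `Cc1c(-c2cc(-c3ccccc3)no2)cnn1C1CCNCC1` bears a plain phenyl there; in an assay on a protein complex for positive allosteric modulation of Neuronal acetylcholine receptor; alpha4/beta2 (Homo sapiens) (a lower number here means a smaller maximal response, a higher number a larger maximal response), compound 1 gives 31%. Compound 2 `Fc1ccc(Cl)c(-c2cc(-c3cnn(C4CCNCC4)c3)on2)c1` carries a 2-chloro-5-fluorophenyl in the same place, and in this assay compound 2 gives 29%. Within the data shown here, of the two numbers known, compound 2 holds the lower one, but its nearest neighbour is compound 1, which lies within the usual scatter of it, so the two cannot be ordered.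

Compound 3 `Clc1sccc1-c1cc(-c2cnn(C3CCNCC3)c2)on1` follows from compound 2 by a single exchange: 2-chlorothiophen-3-yl in place of 2-chloro-5-fluorophenyl on an aromatic carbon. Among the measured compounds shown here, no measured pair yet shows what such an exchange does, so the change can only be judged from the two values at hand, which show that phenyl and chloro-fluorophenyl give much the same maximal response.

The account therefore expects no step beyond the scatter, with a number 1 percentage points higher from compound 2 to compound 3 (within the scatter) as the estimated change. For compound 3 in this assay a maximal response of 30% is expected, within a range from 18% to 45%.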

Compound 3, largest response reached (reported as efficacy), in percent of the reference or control that the assay uses: 42%
Compound 3: middle estimate off by 12 percentage points, on the low side; measured number inside the range.
By their numbers in this assay, from the lowest: compounds 2 and 1 (each within the scatter of the next); then compound 3.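

In this assay, among these compounds, the exchange of 2-chloro-5-fluorophenyl for 2-chlorothiophen-3-yl, on an aromatic carbon of the five-membered aromatic ring with 1 nitrogen and 1 oxygen, gives a number 13 percentage points higher from compound 2 to compound 3 (beyond the scatter) and so provides the first evidence that the maximal response can move at this position with the group placed there. The change is not a single one: the six-membered carbon ring gives way to a five-membered ring with 1 hetero atom, the fluorine leaves, the chlorine stays, and the heavy-atom count falls from 8 to 6, so the step belongs to the exchange as a whole and to no one of these parts. Nothing available accounts for the higher response of compound 3.

The compounds shown leave open whether a 2-chlorophenyl group, which keeps the six-membered ring but has no fluorine, would stand with compound 2 or with compound 3. They also leave open what the chlorine contributes on the thiophene, which a plain thiophen-3-yl group or a 2-methylthiophen-3-yl group at the same place would test.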